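The source may hold more compounds than are shown below. What is called first, only, known or untested is meant among the compounds shown, and "the series" means these compounds.

Three compounds that share a hydroxyphenyl-bearing core with a phenyl group and a thiophene attached were tested in a functional assay on MDA-MB-231 cells (Homo sapiens) for cytotoxicity, read by ELISA, with a stated time of 2 days; on this read-out lower numbers stand for stronger inhibition and higher numbers for weaker inhibition. Compound 1 `Oc1cccc(-c2cc(-c3ccccc3)cc(-c3cccs3)n2)c1` gives 18100 nM in this assay. Compound 2 `Oc1cccc(-c2cc(-c3ccccc3)cc(-c3ccsc3)n2)c1` carries the change thiophen-3-yl in place of thiophen-2-yl on an aromatic carbon relative to compound 1; in this assay compound 2 gives 12100 nM, and the resulting step of a 1.5-fold lower number from compound 1 to compound 2 (0.17 log units; within the scatter) stays small. Compound 3 `Oc1cccc(-c2cc(-c3ccccc3)nc(-c3cccs3)c2)c1` has its core arranged differently from that of compound 1; the difference between the two cores is not broken down here. In this assay compound 3 gives 17700 nM, a number that sits close to those of compound 1 and compound 2, all three lying within the scatter of one another.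

Compound 4 `Oc1cccc(-c2cc(-c3ccccc3)nc(-c3ccsc3)c2)c1` has not yet been measured. It differs from compound 3 by thiophen-3-yl in place of thiophen-2-yl on an aromatic carbon, which is the same change already made from compound 1 to compound 2, at a place described in the same words. Going by the values given here, with only one earlier instance of this change to go on, the expectation is that it behaves the same way again. Because a 1.5-fold lower number from compound 1 to compound 2 (0.17 log units; within the scatter) lay within the scatter, the step toward compound 4 is expected to be a 1.4-fold lower number from compound 3 to compound 4 (0.13 log units; within the scatter). Compound 4 is accordingly estimated to give about 13000 nM in this assay, most likely falling between 6500 nM and 26000 nM.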

Compound 4, half-maximal inhibitory concentration: 19000 nM
Estimate against measurement, compound 4: 1.5-fold (0.16 log units) below; the measured number falls inside the stated range.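

In this assay, replacing thiophen-2-yl with thiophen-3-yl on the second core gives a 1.1-fold higher number from compound 3 to compound 4 (0.03 log units; within the scatter), so this step, like the earlier one, is too small to read as a real change. Set side by side, the two steps do not differ measurably: the same change on two cores in this assay, a 1.5-fold lower number (0.17 log units; within the scatter) from compound 1 to compound 2 and a 1.1-fold higher number (0.03 log units; within the scatter) from compound 3 to compound 4, 1.6-fold (0.21 log units) apart, within the scatter of two such steps This shows that, across these two pairs, the swap between the two thiophene attachments carries from one core to the other without a measurable shift in the number, but it does not show that the two thiophene groups are interchangeable on other cores or in other assays, and neither step gives a direction that could be carried forward.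

All four compounds keep a thiophene, a phenyl group and a 3-hydroxyphenyl group, so the compounds shown leave open how the number would respond to a larger change, such as a furan or a pyridine in place of the thiophene, or an amine, a carboxylic acid or a methoxy group in place of the hydroxyl. They also leave open whether a substituent on the thiophene itself, such as a chlorine or a methyl group, would separate the two attachments in a way that these unsubstituted pairs do not.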